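The source may report more compounds than this note shows. Statements on the series, on what has been measured and on what is new or still open speak of the compounds shown alone.

Three compounds share one core and differ only in the group that sits on an oxygen on a saturated carbon. Compound 1 `CNC(=O)c1cccc(Cn2nc(C)c(NC(=O)c3ccc(COC4CCCCC4)cc3)c2C)c1` carries a cyclohexyl there, and in a functional assay on MIA PaCa-2 cells (Homo sapiens) for antiproliferative activity, read by MTT assay, with a stated time of 72 h (a higher number here means that more compound is needed for the effect, a lower number that less compound is needed), compound 1 gives 14000 nM. Compound 2 `CNC(=O)c1cccc(Cn2nc(C)c(NC(=O)c3ccc(COc4cccc(Cl)c4)cc3)c2C)c1` carries a 3-chlorophenyl instead, and compound 2 gives 5900 nM. Compound 3 `CNC(=O)c1cccc(Cn2nc(C)c(NC(=O)c3ccc(COc4ccccc4C(F)(F)F)cc3)c2C)c1` carries a 2-(trifluoromethyl)phenyl, and compound 3 gives 10000 nM. Among these three numbers compound 3 stands second highest: the step of a 1.4-fold lower number from compound 1 to compound 3 (0.15 log units; within the scatter) is small, and so is the step of a 1.7-fold higher number from compound 2 to compound 3 (0.23 log units; within the scatter). Going by the values given here, only the step of a 2.4-fold lower number from compound 1 to compound 2 (0.38 log units; beyond the scatter) reaches beyond the scatter.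

Compound 4 `CNC(=O)c1cccc(Cn2nc(C)c(NC(=O)c3ccc(COc4ccc(C(F)(F)F)cc4)cc3)c2C)c1` has not yet been measured. Its difference from compound 3 is 4-(trifluoromethyl)phenyl in place of 2-(trifluoromethyl)phenyl on an oxygen on a saturated carbon. Among the compounds with values here, the one measured step that swaps one aromatic group for another on this oxygen is a 1.7-fold higher number from compound 2 to compound 3 (0.23 log units; within the scatter), which stayed within the scatter. The larger step of a 2.4-fold lower number from compound 1 to compound 2 (0.38 log units; beyond the scatter) replaced a saturated ring with an aromatic one, which is not what happens here. The expectation for compound 4 is therefore a step of no change at the digits printed from compound 3 to compound 4 (within the scatter), that is, nothing beyond the scatter. Compound 4 is estimated at 10000 nM, with a range from 4000 nM to 25000 nM.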

Compound 4, half-maximal effective concentration: 800 nM
Compound 4: middle estimate off by 13-fold (1.10 log units), on the high side, and the stated range ends above it.
By their numbers in this assay, from the lowest: compound 4; then compounds 2, 3 and 1 (each within the scatter of the next, the first and the last beyond it).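

In this assay, the step from 2-(trifluoromethyl)phenyl to 4-(trifluoromethyl)phenyl gives a 13-fold lower number from compound 3 to compound 4 (1.10 log units; beyond the scatter), even though the two groups have the same atoms, joined differently. This shows that on this oxygen, where the trifluoromethyl sits on the phenyl ring can matter far more than the earlier swap between aromatic groups suggested. The new group also stands well apart from the other two, with a 7.4-fold lower number from compound 2 to compound 4 (0.87 log units; beyond the scatter) and an 18-fold lower number from compound 1 to compound 4 (1.24 log units; beyond the scatter), while compound 3 remains within the scatter of compound 1, so an aromatic ring on this oxygen does not by itself bring a low number.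

No measurement shown here explains why these two arrangements of the same atoms differ so much in this assay. Also open, going by these compounds, is whether the trifluoromethyl itself matters or whether another group in the same place would serve as well, a question that a 4-chlorophenyl, a 4-methoxyphenyl or a 3-(trifluoromethyl)phenyl on the same oxygen could help to settle.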